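Compound 4 in the series: carbamate on the geranyl core

The compounds below may be only part of what the source reports. "The series", "measured", "known", "first", "only" and "open" are said of these compounds alone.

Three compounds of the series have been run in a functional assay on PANC-1 cells (Homo sapiens) for inhibition, read by MTT assay, with a stated time of 24 h, tested at 10 uM; a higher number here means more inhibition at the concentration tested (going by the name of the read-out), a lower number less inhibition. Compound 1 `CC(C)=CCC/C(C)=C/CC1Cc2c(O)cc(=O)n(CCCO)c2CC1(C)C` gives 28.7%. Compound 2 `COc1cccc(NC(=O)Oc2cc(=O)n(CCCO)c3c2CC(CC=C(C)C)C(C)(C)C3)c1` gives 16.2%. Compound 3 `COc1ccc(OCCCOc2cc(=O)n(CCCO)c3c2CC(C/C=C(\C)CCC=C(C)C)C(C)(C)C3)cc1` gives 20%; on these numbers it stands second highest of the three, nearest compound 2, which lies somewhat lower, and furthest from compound 1, which lies somewhat higher, both gaps within the scatter.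

Going by the values given here, the one measured step is a number 8.7 percentage points lower from compound 1 to compound 3 (within the scatter), so the ether chain on the core of compound 1 does not move this assay beyond the scatter. Compound 4 `COc1cccc(NC(=O)Oc2cc(=O)n(CCCO)c3c2CC(C/C=C(\C)CCC=C(C)C)C(C)(C)C3)c1` is not yet measured. It differs from compound 3 thus: (3-methoxyphenyl)carbamoyl in place of 3-(4-methoxyphenoxy)propyl on an oxygen on an aromatic ring. Among the compounds with values here, no measured step covers this exchange directly. Compound 2 carries the same carbamate on the shorter side chain and gives 16.2%, while compound 3 gives 20%, the two within the scatter of each other. Within the data shown here, nothing among the measured values therefore points to a step beyond the scatter in this assay, and the expected step is a number 3 percentage points lower from compound 3 to compound 4 (within the scatter).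

Compound 4 is accordingly estimated at 17%, with a range from 8% to 28%.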

Compound 4, a percentage reported as inhibition, at one concentration (the size of the read-out at that concentration, not a potency): 47%
Beside the measured number, compound 4's estimate is 30 percentage points below it; the measured number lies above the stated range.
By their numbers in this assay, from the lowest: compounds 2, 3 and 1 (each within the scatter of the next, the first and the last beyond it); then compound 4.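

In this assay this oxygen on an aromatic ring proves responsive to the group it carries: (3-methoxyphenyl)carbamoyl in place of hydrogen gives a number 18.3 percentage points higher from compound 1 to compound 4 (beyond the scatter) and, in place of 3-(4-methoxyphenoxy)propyl, gives a number 27 percentage points higher from compound 3 to compound 4 (beyond the scatter), steps beyond the scatter that the ether chain alone did not produce. The carbamate does not act the same way on every side chain, since adding 3-methylbut-2-en-1-yl on a saturated chain carbon bound to a double-bonded chain carbon gives a number 30.8 percentage points higher from compound 2 to compound 4 (beyond the scatter), so compound 2 and compound 4 together tie the high reading to this carbamate and the longer side chain in combination, not to the carbamate alone. No measurement at hand speaks to what lies behind these steps.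

The compounds shown leave open whether a urea or a plain ester on this oxygen would hold the higher reading, and whether the carbamate needs its methoxy group or would do the same with an unsubstituted phenyl ring. They also leave open whether a side chain longer than that of compound 4 would carry the trend further, and how these single-concentration readings would translate into potency.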